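The source may hold more compounds than are shown below. What is called first, only, known or untested is meant among the compounds shown, and "the series" means these compounds.

Compound 1 `N#Cc1ccc(N2CCc3cc(-c4cncnc4)ccc32)cc1C(F)(F)F`: "not determined" (no result reported)
Compound 2 `N#Cc1ccc(N2CCCc3c(-c4cccnc4)cccc32)cc1C(F)(F)F`: 13500 nM
Compound 3 `CCN(c1ccc(C#N)c(Cl)c1)c1cc(-c2ccccc2)ccc1C`: > 30000 nM

These results come from a functional assay on VCaP cells (Homo sapiens) for antiproliferative activity, read by CCK-8 assay, with a stated time of 6 days; a lower number here means a stronger inhibitor, a higher number a weaker inhibitor. Among them, compound 2 gives the only actual number, 13500 nM. Compound 1 has no reported result, so it offers no comparison. Compound 3 gives only a limit of the assay, > 30000 nM, and not a number.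

The next compound, compound 4 `Cc1noc(C)c1-c1cccc2c1CCCN2c1ccc(C#N)c(C(F)(F)F)c1`, differs from compound 2 at a single place: 3,5-dimethyl-1,2-oxazol-4-yl in place of pyridin-3-yl on an aromatic carbon. A 3,5-dimethyl-1,2-oxazol-4-yl group replaces the pyridin-3-yl group on an aromatic carbon, and the rest of the molecule stays the same. Within the data shown here, no measured pair here shows what this exchange does, so compound 2, at 13500 nM, is the only anchor. In this assay, no step beyond the usual scatter is expected, with only a slight lean towards a stronger inhibitor. The expected change is a 1.5-fold lower number from compound 2 to compound 4 (0.18 log units; within the scatter). For compound 4, the estimated value is 9000 nM, with an expected range of 2000 nM to 30000 nM.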

Compound 4, half-maximal inhibitory concentration: > 30000 nM
Compound 4: a limit, no number (the forecaster's own chance of this, stated with the estimate: 25%); middle value at least 3.3-fold (0.52 log units) away from the limit.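

Placing 3,5-dimethyl-1,2-oxazol-4-yl instead of pyridin-3-yl on this aromatic carbon gives the first measured step at this position in this assay, and it runs towards a weaker inhibitor: an at least 2.2-fold higher number from compound 2 to compound 4 (0.34 log units; beyond the scatter). Compound 4 gives > 30000 nM, which is a limit of the assay and not a number. The step therefore sets only a minimum for the change, and its true size remains unknown, with the limit reached by more than one compound here: the limit of > 30000 nM in this assay, at which 2 of the 4 values shown sit.

This single pair changes the ring size, the hetero atoms and the two methyl groups all at once, so it cannot show which of these differences matters. Going by these compounds, how an amine, a carboxylic acid or a morpholine ring on this same carbon would read out also remains open.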